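The source may report more compounds than this note shows. Statements on the series, on what has been measured and on what is new or still open speak of the compounds shown alone.

Compound 2 `CCOC(=O)C1=C(C)N/C(=C/c2cc(C)n(-c3ccc(Br)cc3)c2C)C1=O` carries a 4-bromophenyl group on the aromatic nitrogen of its core. In a physicochemical assay for solubility, read by nephelometry, measured as kinetic solubility, at pH 2.0 (on this read-out higher numbers stand for higher solubility and lower numbers for lower solubility), compound 2 gives 2.1 ug/mL, the highest of the three numbers recorded. Compound 1 `CCOC(=O)C1=C(C)N/C(=C/c2cc(C)n(-c3cccc(C(F)(F)F)c3)c2C)C1=O` gives 1 ug/mL, and compound 3 `CCOC(=O)C1=C(C)N/C(=C/c2cc(C)n(-c3ccc(SC(F)(F)F)cc3)c2C)C1=O` gives 1 ug/mL. The step of a 2.1-fold higher number from compound 1 to compound 2 (0.32 log units; beyond the scatter) and the step of a 2.1-fold lower number from compound 2 to compound 3 (0.32 log units; beyond the scatter) each came from exchanging the aryl group on that nitrogen, and each was modest. Compound 4 `CCOC(=O)C1=C(C)N/C(=C/c2cc(C)n(-c3ccncc3)c2C)C1=O` is not yet measured; it differs from compound 2 in one place: pyridin-4-yl in place of 4-bromophenyl on an aromatic nitrogen. Since the two measured exchanges at this position gave only modest steps, a modest step in this assay is expected here too, more likely upward than downward. For compound 4 the expected value is 4 ug/mL, within 1.5 ug/mL to 12 ug/mL, an expected step of a 1.9-fold higher number from compound 2 to compound 4 (0.28 log units; within the scatter).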

Compound 4, solubility: 100 ug/mL
The estimate for compound 4 lay 25-fold (1.40 log units) below the measured number; the measured number lies above the stated range.
By their numbers in this assay, from the lowest: compounds 1 and 3 (each within the scatter of the next); then compound 2; then compound 4.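

In this assay, the group on the aromatic nitrogen proves able to move the read-out much further than the earlier exchanges showed: pyridin-4-yl gives a 48-fold higher number from compound 2 to compound 4 (1.68 log units; beyond the scatter), and a 100-fold higher number from compound 1 to compound 4 (2.00 log units; beyond the scatter). Both steps are large, whereas compounds 1, 2 and 3, whose rings are of carbon only, differ by modest steps; the entering ring has one hetero atom and one hydrogen-bond acceptor. No measurement here explains the jump. The compounds shown leave open whether pyridin-3-yl would give a similar step, or whether a phenyl ring carrying an amine or a carboxylic acid would.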